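Methoxyphenyl for chlorophenyl, carried onto a second core

This account rests on a few compounds, and the source may have more. Where it says the series, first, only, none or still open, it means among the compounds named here.

Compound 1 `COc1ccc(S(=O)(=O)c2cnc3c(F)cccc3c2-c2cccc(Cl)c2)cc1` and compound 2 `COc1ccc(-c2c(S(=O)(=O)c3ccc(OC)cc3)cnc3c(F)cccc23)cc1` share one core; compound 3 `O=S(=O)(c1cc(Cl)cc(Cl)c1)c1cnc2cc(F)ccc2c1-c1cccc(Cl)c1` sits on a second core, and compound 4 `COc1ccc(-c2c(S(=O)(=O)c3cc(Cl)cc(Cl)c3)cnc3cc(F)ccc23)cc1` is the unmeasured partner of compound 3 on that core. In an ADME assay on microsomes from liver (Homo sapiens) for metabolic stability, tested at 2.5 uM (on this read-out higher numbers stand for fast clearance and lower numbers for slow clearance), compound 1 gives 2.75 mL/min, compound 2 gives 2.12 mL/min and compound 3 gives 0.93 mL/min; compound 3 stands lowest of the three, beyond the scatter from each of the others. The difference between the two cores is not broken down here.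

The change from compound 1 to compound 2 is 4-methoxyphenyl in place of 3-chlorophenyl on an aromatic carbon and made a 1.3-fold lower number from compound 1 to compound 2 (0.11 log units; within the scatter). The same change, (4-methoxyphenyl in place of 3-chlorophenyl on an aromatic carbon), takes compound 3 to compound 4, at a place that is the same word for word. In this assay, among the compounds with values here, the expected step is a 1.2-fold lower number from compound 3 to compound 4 (0.09 log units; within the scatter), resting on the single measured pair, where a 1.3-fold lower number from compound 1 to compound 2 (0.11 log units; within the scatter) lay within the scatter, so no firm direction can be read from it and the step is expected to be small. Compound 4 is therefore expected to come out near 0.75 mL/min, between 0.4 mL/min and 1.45 mL/min.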

Compound 4, intrinsic clearance in a liver preparation (reported as CLH), per the amount of preparation that the assay uses: 1 mL/min
Estimate against measurement, compound 4: 1.3-fold (0.12 log units) below, within the range that was stated.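

In this assay, 4-methoxyphenyl in place of 3-chlorophenyl on the second core gives a 1.1-fold higher number from compound 3 to compound 4 (0.03 log units; within the scatter), so the step is small here as it was on the first core. Set side by side, the two steps do not differ: the same change on two cores in this assay, a 1.3-fold lower number (0.11 log units; within the scatter) from compound 1 to compound 2 and a 1.1-fold higher number (0.03 log units; within the scatter) from compound 3 to compound 4, 1.4-fold (0.14 log units) apart, within the scatter of two such steps This shows that, on these two cores, the change leaves the clearance number within the scatter and that a small step carried over from one core to the other, but it gives no direction for the change, no reason for its small size, and no basis for extending the result to other cores in the series.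

The compounds shown leave open whether a different group on this aromatic carbon, such as an amine, a carboxylic acid or a longer alkyl chain, would move the number beyond the scatter. They also leave open which of the differences between the two cores accounts for the gap between them, as no pair shown isolates any one of those differences.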